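The compounds below may be only part of what the source reports. "The series", "measured", "known", "first", "only" and "open" are said of these compounds alone.

Three compounds have been measured in a functional assay on A549 cells (Homo sapiens), read by MTT assay, with a stated time of 72 h; a lower number here means a stronger inhibitor, a higher number a weaker inhibitor:

compound 1 `COc1ncnc2c1c(-c1ccsc1)cn2[C@@H]1O[C@H](CO)[C@@H](O)[C@H]1O` gives 5170 nM
compound 2 `COc1nc(N)nc2c1c(-c1ccsc1)cn2[C@@H]1O[C@H](CO)[C@@H](O)[C@H]1O` gives > 100000 nM, which is a limit of the assay rather than a number
compound 3 `O=c1[nH]cnc2c1c(-c1cc3ccccc3o1)cn2[C@@H]1O[C@H](CO)[C@@H](O)[C@H]1O` gives > 20000 nM, again a limit of the assay rather than a number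

Compound 1 and compound 3 share the sugar but carry different cores; the difference between the two cores is not broken down here. From compound 1 to compound 2 the change is amino in place of hydrogen on an aromatic carbon, and it costs a great deal of activity: an at least 19-fold higher number from compound 1 to compound 2 (1.28 log units; beyond the scatter), with compound 2 sitting at the limit of > 100000 nM in this assay, at which 1 of the 3 values shown sits.

Compound 4 `Nc1nc2c(c(-c3cc4ccccc4o3)cn2[C@@H]2O[C@H](CO)[C@@H](O)[C@H]2O)c(=O)[nH]1` has not yet been measured. It comes from compound 3 by amino in place of hydrogen on an aromatic carbon. Among the compounds with values here, this is the same kind of change as the one from compound 1 to compound 2, though not the same: there the amino group stands meta to a methoxy group (2 heavy atoms), here meta to a group of 1 heavy atom.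

For compound 4 a weakening step that the limit leaves unreadable from compound 3 to compound 4 is expected. That expectation rests on the large loss an at least 19-fold higher number from compound 1 to compound 2 (1.28 log units; beyond the scatter) and on compound 3 already sitting at the limit of > 20000 nM in this assay, at which 1 of the 3 values shown sits. Compound 4 is therefore estimated at 100000 nM, most likely between 20000 nM and 500000 nM, and most probably reported only as a limit.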

Compound 4, half-maximal inhibitory concentration: > 100000 nM
Compound 4: only a limit was reported (the forecaster's own chance of this, stated with the estimate: 85%); the middle value sits exactly at the limit.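

In this assay compound 3 gives > 20000 nM, which is a limit of the assay. Within the data shown here, compound 4 gives > 100000 nM, also a limit, and no step from compound 3 to compound 4 can be read. The compounds shown leave open whether amino in place of hydrogen weakens activity on the core of compound 3 at all.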